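This account rests on a few compounds, and the source may have more. Where it says the series, first, only, none or still open, it means among the compounds named here.

Compound 2, `CCCC(O)(C#Cc1ccc(C(CC)(CC)C2=CCC(C(=O)NCCN(CC)CC)N2CC)cc1C)CCC`, gives 52.1% in an assay on isolated protein for binding affinity to vitamin D3 receptor (Homo sapiens), read by fluorescence polarization, tested at 1 uM; a higher number here means more inhibition at the concentration tested (going by the name of the read-out), a lower number less inhibition. On the two numbers shown it stands at the top, yet compound 1, `CCN(CC)CCNC(=O)C1CC(C(CC)(CC)c2ccc(C#CC(O)C3CCC3)c(C)c2)=CN1CC`, gives 49.3% in this assay, and that number lies within the scatter of compound 2, so the two cannot be told apart. Compound 3, `CCN(CC)CCNC(=O)C1CC=C(C(CC)(CC)c2ccc(/C=C/C(C)(O)CC)c(C)c2)N1CC`, has not yet been measured. It differs from compound 2 in one place: a group of 7 heavy atoms (6 carbon, 1 oxygen; no ring) in place of a group of 10 heavy atoms (9 carbon, 1 oxygen; no ring), on an aromatic carbon. Among the measured compounds shown here, no pair of measured compounds that differ in a single place is in hand, so there is no measured step to lean on, and the expectation rests on compound 1 and compound 2 alone, whose values sit close together. Compound 3 is expected to land near those two, with a small downward step a number 7.1 percentage points lower from compound 2 to compound 3 (within the scatter) or none beyond the scatter. The estimate for compound 3 in this assay is 45%, with a range from 25% to 65%.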

Compound 3, a percentage reported as inhibition, at one concentration (the size of the read-out at that concentration, not a potency): 68.9%
Beside the measured number, compound 3's estimate is 23.9 percentage points below it; the measured number lies above the stated range.
By their numbers in this assay, from the lowest: compounds 1 and 2 (each within the scatter of the next); then compound 3.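

Among the compounds shown here, the aromatic carbon ortho to a methyl group and para to a large group proves sensitive to what it carries: in this assay the exchange gives a number 16.8 percentage points higher from compound 2 to compound 3 (beyond the scatter) and is the first change in a single place to be read. The group of 7 heavy atoms, with 1 double bond outside aromatic rings, and the group of 10 heavy atoms, with 1 triple bond outside aromatic rings, each hold 1 hydrogen-bond donor and 1 hydrogen-bond acceptor, so the step comes without any change in those counts. No measurement at hand gives a reason for the step.

Group size and bond type change together here, and this single step cannot separate them. Also open, going by these compounds, is how this position would respond to a group carrying an amine or a carboxylic acid, or to a longer chain.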